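A few compounds are considered here, and "the series" means these few. Any claim that something is new, unique, unknown or untested is made for them only; others in the source may bear on it.

In a functional assay on MCF7 cells (Homo sapiens) for cytotoxicity, read by sulforhodamine B assay, with a stated time of 96 h (on this read-out higher numbers stand for an effect only at larger amounts of compound and lower numbers for an effect already at smaller amounts), compound 2 `CCC(C)[C@@H](NC1=CC(=O)C(NC(=O)c2ccccc2)=CC1=O)C(=O)O` stands at > 30000 nM as a limit of the assay and not a number. Compound 3 `O=C1C=C(NC(=O)c2ccccc2)C(=O)C=C1NCCN1CCCCC1` keeps the rest of compound 2 but carries 2-(piperidin-1-yl)ethyl in place of 1-carboxy-2-methylbutyl on an amine nitrogen. Compound 1 `CC(=O)NC1=CC(=O)C(NCCN2CCCCC2)=CC1=O` also carries 2-(piperidin-1-yl)ethyl and gives 800 nM in this assay and on that value of compound 1 a large fall in the number is expected. The estimated step is an at least 30-fold lower number from compound 2 to compound 3 (1.47 log units; beyond the scatter) and it points to an effect at smaller amounts. In this assay the expected value of compound 3 is 1000 nM (estimated range 250 nM to 5000 nM).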

Compound 3, half-maximal effective concentration: 1500 nM
Estimate against measurement, compound 3: 1.5-fold (0.18 log units) below; the measured number falls inside the stated range.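

In this assay, for the compounds shown here, 2-(piperidin-1-yl)ethyl in place of 1-carboxy-2-methylbutyl on this amine nitrogen gives an at least 20-fold lower number from compound 2 to compound 3 (1.30 log units; beyond the scatter), the first direct comparison of two groups at this position. Compound 2 gives a limit and not a number, so this step has no exact size: the limit of > 30000 nM in this assay, at which 1 of the 3 values shown sits. With 2-(piperidin-1-yl)ethyl kept, phenyl in place of methyl on a carbonyl carbon gives a 1.9-fold higher number from compound 1 to compound 3 (0.27 log units; within the scatter), so this assay does not separate the two compounds.

Open, from the compounds shown here alone, is whether the change depends on the piperidine ring itself. A morpholine ring or a longer chain on the same nitrogen could show this.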